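Chloromethyl replacement on the shared core: antiproliferative series

The source may report more compounds than this note shows. Statements on the series, on what has been measured and on what is new or still open speak of the compounds shown alone.

Measured so far:
compound 1 `CC(C)=CCC[C@]1(C)/C=C/[C@@H](OC(=O)C=C(C)C)[C@](C)(O)/C=C/C(=O)/C(CCl)=C\C1` — 840 nM
compound 2 `CC(C)=CCC[C@]1(C)/C=C/[C@@H](OC(=O)C=C(C)C)[C@](C)(O)/C=C/C(=O)/C(C[Si](c2ccccc2)(c2ccccc2)C(C)(C)C)=C\C1` — 38000 nM

In a functional assay on SMMC-7721 cells (Homo sapiens) for antiproliferative activity, read by MTT assay, with a stated time of 48 h (on this read-out higher numbers stand for weaker inhibition and lower numbers for stronger inhibition), compound 1 gives 840 nM, the lowest number of the two. Compound 2, which carries a large silyl substituent at the same ring carbon, gives 38000 nM in this assay, a gap well beyond the usual scatter.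

Compound 3 `CC(C)=CCC[C@]1(C)/C=C/[C@@H](OC(=O)C=C(C)C)[C@](C)(O)/C=C/C(=O)/C(C(=O)N(C)C)=C\C1` differs from compound 1 only at this position: dimethylcarbamoyl in place of chloromethyl on a double-bonded ring carbon. Going by the values given here, no measured pair isolates this exact exchange, so the expectation rests on compound 1 and compound 2 alone. Both of the two measured compounds differ at this ring carbon, and compound 2, which lacks chloromethyl, gives the much higher number 38000 nM. A weakening step from compound 1 to compound 3 is therefore expected, a 12-fold higher number from compound 1 to compound 3 (1.08 log units; beyond the scatter), though probably smaller than that seen for compound 2. Compound 3 is expected to give 10000 nM in this assay, within 3000 nM to 40000 nM.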

Compound 3, half-maximal inhibitory concentration: 3670 nM
The estimate for compound 3 lay 2.7-fold (0.44 log units) above the measured number, and the stated range covers the measured number.
By their numbers in this assay, from the lowest: compound 1; then compound 3; then compound 2.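

In this assay, chloromethyl at this double-bonded ring carbon can give way to dimethylcarbamoyl at a modest cost, a 4.4-fold higher number from compound 1 to compound 3 (0.64 log units; beyond the scatter). Chloromethyl is therefore not required for activity in this series: compound 3, which has no chlorine, gives 3670 nM, a lower number than compound 2 at 38000 nM. No measurement shown accounts for the size of this step.

Still open, from the compounds shown here alone, is whether a hydroxymethyl group, a primary amide or a carboxylic acid at this ring carbon would give a number closer to compound 1 or to compound 3. Also open, going by these compounds, is whether the order of compound 1, compound 3 and compound 2 holds in other cell lines.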